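This account rests on a few compounds, and the source may have more. Where it says the series, first, only, none or still open, it means among the compounds named here.

Measured compounds:
- compound 1, `CC(C)OC(=O)NCCS(=O)(=O)NC(=O)c1ccc(Nc2nc(NC3(c4ccc(Cl)cc4)CC3)nc(OCC(F)(F)F)n2)cc1`; in a physicochemical assay for permeability, using PAMPA, at pH 7.4 (a lower number here means that the compound crosses the layer more slowly, a higher number that the compound crosses the layer faster), compound 1 gives 71 nm/s
- compound 2, `CC(C)C(=O)NCCS(=O)(=O)NC(=O)c1ccc(Nc2nc(NC3(c4ccc(Cl)cc4)CC3)nc(OCC(F)(F)F)n2)cc1`; compound 2 gives 13 nm/s
- compound 3, `CCS(=O)(=O)NC(=O)c1ccc(Nc2nc(NC3(c4ccc(Cl)cc4)CC3)nc(OCC(F)(F)F)n2)cc1`; compound 3 gives 28 nm/s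

Compound 3 holds the second highest of the three numbers: it sits a 2.2-fold higher number from compound 2 to compound 3 (0.33 log units; beyond the scatter) and a 2.5-fold lower number from compound 1 to compound 3 (0.40 log units; beyond the scatter). Compound 4, `CC(C)NC(=O)NCCS(=O)(=O)NC(=O)c1ccc(Nc2nc(NC3(c4ccc(Cl)cc4)CC3)nc(OCC(F)(F)F)n2)cc1`, differs from compound 3 by (isopropylcarbamoyl)amino in place of hydrogen on a saturated chain carbon, two bonds along the chain from a sulfonyl sulfur. Going by the values given here, two measured steps bear on this change, each adding a group at the same place on the chain: the carbonyl-bearing group of compound 2 gave a modest drop, seen in reverse as a 2.2-fold higher number from compound 2 to compound 3 (0.33 log units; beyond the scatter), while the group of compound 1 raised the number, seen in reverse as a 2.5-fold lower number from compound 1 to compound 3 (0.40 log units; beyond the scatter). A modest decrease for compound 4 is therefore expected, a 2.5-fold lower number from compound 3 to compound 4 (0.41 log units; beyond the scatter). Compound 4 is estimated at 11 nm/s, in the range 4 nm/s to 28 nm/s.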

Compound 4, apparent permeability: 45 nm/s
Beside the measured number, compound 4's estimate is 4.1-fold (0.61 log units) below it; measured number above the stated range.
By their numbers in this assay, from the lowest: compound 2; then compounds 3, 4 and 1 (each within the scatter of the next, the first and the last beyond it).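

In this assay, putting (isopropylcarbamoyl)amino on this saturated chain carbon leaves compound 4 within the scatter of the compound without it (a 1.6-fold higher number from compound 3 to compound 4 (0.21 log units; within the scatter)). On the carbonyl carbon, isopropylamino in place of isopropyl gives a step beyond the scatter (a 3.5-fold higher number from compound 2 to compound 4 (0.54 log units; beyond the scatter)), whereas isopropylamino in place of isopropoxy stays within it (a 1.6-fold lower number from compound 1 to compound 4 (0.20 log units; within the scatter)). Nothing measured here gives a reason for this difference. Still open, as far as these compounds go, is how a carboxylic acid or an amine at this chain position would read, and whether a longer chain would keep these numbers.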